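Shortening the Chain on a Cyanoaziridine Urea

This account rests on a few compounds, and the source may have more. Where it says the series, first, only, none or still open, it means among the compounds named here.

Measured compounds:
- compound 1, `CCCCNC(=O)N1CC1C#N`: 17000 nM
- compound 2, `CC(=O)c1cccc(NC(=O)N2CC2C#N)c1`: 8700 nM
- compound 3, `N#CC1CN1C(=O)Nc1cccc2ccccc12`: 8000 nM

In a functional assay on RPMI-8226 cells (Homo sapiens) for inhibition (on this read-out higher numbers stand for weaker inhibition and lower numbers for stronger inhibition), compound 1 gives the highest of the three numbers, meaning the weakest inhibition in this set. Against compound 2 the gap falls within the usual scatter, so the two cannot be told apart; against compound 3 the gap lies beyond the scatter, so compound 3 is the stronger inhibitor of that pair. All three share the same core, a nitrile-bearing three-membered ring carrying a urea, and differ only in the group on the urea nitrogen.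

Compound 4, `CCNC(=O)N1CC1C#N`, keeps that core and trims the chain of compound 1: hydrogen in place of ethyl on a saturated chain carbon, two bonds along the chain from an amide-type nitrogen. Nothing measured here shows what a shorter chain does, so the expectation rests on the change being small and remote from the urea. The step from compound 1 to compound 4 is expected to be a 1.5-fold higher number from compound 1 to compound 4 (0.17 log units; within the scatter), at most a modest loss, possibly none beyond the scatter. Compound 4 is therefore estimated at 25000 nM, with a plausible range from 9000 nM to 70000 nM.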

Compound 4, half-maximal inhibitory concentration: 22000 nM
The estimate for compound 4 lay 1.1-fold (0.06 log units) above the measured number, within the range that was stated.
By their numbers in this assay, from the lowest: compounds 3, 2, 1 and 4 (each within the scatter of the next, the first and the last beyond it).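

In this assay the step reads a 1.3-fold higher number from compound 1 to compound 4 (0.11 log units; within the scatter), so compounds 1 and 4 cannot be told apart. Within the data shown here, this is the first pair in the set that differs in one place only, and it shows that going from butyl to ethyl on this chain leaves no effect that this measurement can resolve, even with two carbons gone. No other measurement here bears on this result.

On these data alone, whether the chain can be trimmed further to methyl without a clear change in this read-out remains open. So does the effect of a longer chain such as hexyl, or of a chain ending in an amine or a carboxylic acid, at this same place on the shared core.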